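Replacing benzyloxy with methylsulfanyl on a growth inhibitor

A few compounds are considered here, and "the series" means these few. Any claim that something is new, unique, unknown or untested is made for them only; others in the source may bear on it.

Of the compounds shown here, two have so far been measured in a functional assay on DU-145 cells (Homo sapiens) for inhibition, read by trypan blue exclusion, with a stated time of 96 h (a lower number here means a stronger inhibitor of growth, a higher number a weaker inhibitor of growth), on the shared core. In this assay compound 1 (`Cc1cc(C)cc(/C=C(\C(=O)c2ccc(Cl)cc2)S(=O)(=O)Cc2ccc(Cl)cc2)c1`) gives 1000 nM and compound 2 (`O=C(/C(=C\c1ccc(OCc2ccccc2)cc1)S(=O)(=O)Cc1ccc(Cl)cc1)c1ccc(Cl)cc1`) gives 1000 nM at the digits reported, which places compound 2 level with compound 1.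

Compound 3 (`CSc1ccc(/C=C(\C(=O)c2ccc(Cl)cc2)S(=O)(=O)Cc2ccc(Cl)cc2)cc1`) awaits measurement and differs from compound 2 at a single place, on an aromatic carbon of a six-membered aromatic ring of carbon only, para to a large group. It carries methylsulfanyl in place of benzyloxy (methylsulfanyl in place of benzyloxy on an aromatic carbon).

Among the compounds with values here, no measured pair in this small set differs at one place alone, so the expectation has no direct precedent and remains uncertain. Taking compound 2 at 1000 nM as the starting point, no step beyond the usual scatter is expected in this assay in either direction. The estimate amounts to no change at the digits printed from compound 2 to compound 3 (within the scatter) as the expected change. For compound 3 the estimated value is 1000 nM with an expected range from 300 nM to 3000 nM at the upper end.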

Compound 3, concentration for 50% growth inhibition: 10000 nM
Compound 3: the middle estimate sits 10-fold (1.00 log units) below what was measured; measured number above the stated range.
By their numbers in this assay, from the lowest: compounds 1 and 2 (each within the scatter of the next); then compound 3.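

In this assay, within the data shown here, methylsulfanyl in place of benzyloxy on an aromatic carbon, para to a large group, brings a 10-fold higher number from compound 2 to compound 3 (1.00 log units; beyond the scatter) and gives the first step in this set that lies beyond the scatter. The comparison of 4-(methylsulfanyl)phenyl in place of 3,5-dimethylphenyl on a double-bonded chain carbon gives a 10-fold higher number from compound 1 to compound 3 (1.00 log units; beyond the scatter) as well, which leaves compound 3 as the weakest growth inhibitor of the three. The position therefore responds to what it carries, and on the shared core the exchange of the eight-heavy-atom benzyloxy for the two-heavy-atom methylsulfanyl costs activity rather than leaving it unchanged. No measurement in hand bears on why the number rises.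

The compounds shown do not separate the loss of the benzyl ring from the arrival of sulfur, which a methoxy or a benzylsulfanyl group at the same place could tell apart. From the compounds shown here alone, it also remains open how this position would answer to an amine or a carboxylic acid, and whether any group there could bring the number lower than that of compound 2.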